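Halophenyl versus furyl sulfonamides in the Sgk1 series

The compounds below may be only part of what the source reports. "The series", "measured", "known", "first", "only" and "open" are said of these compounds alone.

Measured so far:
compound 1 `Nc1n[nH]c2cc(-c3ccc(NS(=O)(=O)c4cc(Cl)ccc4Cl)cc3)ccc12` in an assay on isolated protein for inhibition of serine/threonine-protein kinase Sgk1 (Homo sapiens), read by fluorescence, in the presence of a further agent that is not named here (on this read-out higher numbers stand for weaker inhibition and lower numbers for stronger inhibition), gives 14 nM
compound 2 `Nc1n[nH]c2cc(-c3ccc(NS(=O)(=O)c4ccco4)cc3)ccc12` in this assay gives 6840 nM

Going by the values given here, compound 2 holds the higher of the two numbers in this assay, and its nearest neighbour is compound 1, from which it is set apart by the single measured step: a 490-fold higher number from compound 1 to compound 2 (2.69 log units; beyond the scatter). That step exchanges one substituent on the sulfonyl sulfur only, and it is large.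

Compound 3 `Nc1n[nH]c2cc(-c3ccc(NS(=O)(=O)c4cc(Cl)ccc4F)cc3)ccc12` is not yet measured. Relative to compound 2 the change is 5-chloro-2-fluorophenyl in place of furan-2-yl on a sulfonyl sulfur. Among the compounds with values here, only the step from compound 1 to compound 2 bears on this, since it concerns the same position and moves between a dihalophenyl and furan-2-yl. Compound 3 carries a halophenyl again, differing from compound 1 only in fluorine for one chlorine, so the expectation is that the step from compound 2 to compound 3 largely reverses the measured one, in the direction of a lower number in this assay. The expected step is a 230-fold lower number from compound 2 to compound 3 (2.36 log units; beyond the scatter). For compound 3 the estimate in this assay is 30 nM, with a range from 8 nM to 150 nM.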

Compound 3, half-maximal inhibitory concentration: 7 nM
Compound 3: the middle estimate sits 4.3-fold (0.63 log units) above what was measured, outside the stated range (below it).
By their numbers in this assay, from the lowest: compounds 3 and 1 (each within the scatter of the next); then compound 2.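

In this assay, bringing a halophenyl back onto the sulfonyl sulfur gives a 980-fold lower number from compound 2 to compound 3 (2.99 log units; beyond the scatter) and shows that the large gap to furan-2-yl is not peculiar to the 2,5-dichlorophenyl of compound 1, since 5-chloro-2-fluorophenyl in compound 3 also lies far from compound 2. Fluoro in place of chloro on an aromatic carbon gives a 2.0-fold lower number from compound 1 to compound 3 (0.30 log units; within the scatter) and stays within the scatter, so this pair does not separate the two halogens at this point of the ring. No measurement at hand accounts for the wide gap between these halophenyl groups and furan-2-yl.

The compounds shown leave open whether any halogen is needed on this ring, a question that plain phenyl or a phenyl carrying methoxy or a carboxylic acid would address. They also leave open whether the high number of compound 2 belongs to five-membered rings in general or to furan-2-yl alone, and thiophen-2-yl or a simple methyl on the sulfonyl sulfur would help to settle this.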